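Indole amide and amine series: aromatic nitrogen methylation

This account rests on a few compounds, and the source may have more. Where it says the series, first, only, none or still open, it means among the compounds named here.

Measured so far:
compound 1, `Cn1c(C(=O)Nc2ccccc2)cc2ccccc21`: 100000000 nM
compound 2, `O=C(NCCCCc1ccccc1)c1cc2ccccc2[nH]1`: 455000000 nM
compound 3, `c1ccc(NCc2cc3ccccc3[nH]2)cc1`: 100000000 nM

All three numbers come from an assay on isolated protein for inhibition of Amine oxidase [flavin-containing] A (Homo sapiens); on this read-out lower numbers stand for stronger inhibition and higher numbers for weaker inhibition. Compound 3 stands level with compound 1 at the digits shown, the two within the scatter of each other, while compound 2 sits at a higher number than compound 3 by a margin beyond the scatter. None of the three reaches a number that would count as meaningful inhibition.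

Compound 4, `Cn1c(CNc2ccccc2)cc2ccccc21`, is compound 3 with methyl in place of hydrogen on an aromatic nitrogen. Compound 1 already carries this methyl on the aromatic nitrogen and is level with compound 3 in this assay, so for compound 4 no step beyond the scatter is expected in either direction. The estimated value for compound 4 is 100000000 nM (range 40000000 nM to 300000000 nM), which means an expected step of no change at the digits printed from compound 3 to compound 4 (within the scatter).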

Compound 4, inhibition constant: 10000000 nM
Beside the measured number, compound 4's estimate is 10-fold (1.00 log units) above it; measured number outside the range, below it.
By their numbers in this assay, from the lowest: compound 4; then compounds 1 and 3 (each within the scatter of the next); then compound 2.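

In this assay, among these compounds, methyl in place of hydrogen on the aromatic nitrogen gives a 10-fold lower number from compound 3 to compound 4 (1.00 log units; beyond the scatter) and so shows that this position responds to substitution, which the earlier compounds could not show. Even so, compound 4 gives 10000000 nM as its value, still not a number that counts as meaningful inhibition. No measurement at hand explains the step.

Open, on these data alone, is whether ethyl or a longer chain on this aromatic nitrogen moves the number further. Also open, as far as these compounds go, is whether methyl at this position gives a similar step on compound 2.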